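Shifting the pyridine attachment point in a weak antiproliferative series

This account rests on a few compounds, and the source may have more. Where it says the series, first, only, none or still open, it means among the compounds named here.

Measured compounds in a functional assay on HeLa cells (Homo sapiens) for antiproliferative activity, read by MTT assay, with a stated time of 48 h; on this read-out higher numbers stand for weaker inhibition and lower numbers for stronger inhibition:
Compound 1, `O=C(CSc1nnc(NC(=O)c2c(Cl)cccc2Cl)s1)Nc1ccc(Br)cn1`, gives 25800 nM.
Compound 2, `COc1ccccc1C(=O)Nc1nnc(SCC(=O)Nc2ccc(C)cn2)s1`, gives > 80000 nM.

Compound 2 stands at a limit rather than a number: its result is the limit of > 80000 nM in this assay, at which 1 of the 2 values shown sits, so only a floor for its inhibitory concentration is known. Compound 3, `COc1ccccc1C(=O)Nc1nnc(SCC(=O)Nc2c(C)ccnc2Cl)s1`, differs from compound 2 by 2-chloro-4-methylpyridin-3-yl in place of 5-methylpyridin-2-yl on an amide-type nitrogen. Within the data shown here, with no measured pair of this kind to lean on, the expected step from compound 2 to compound 3 in this assay is a number no higher from compound 2 to compound 3 (the limit leaves the size open), that is, none beyond the scatter. Compound 3 is therefore estimated at 80000 nM, with a range from 30000 nM to 200000 nM, and most likely again only a limit.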

Compound 3, half-maximal inhibitory concentration: > 80000 nM
Compound 3 gave a limit, no number; the forecaster's own chance of this, stated with the estimate: 70%; the middle value lies on the limit itself.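

Compound 2 and compound 3 both sit at a limit, so no step can be read between them: the limit of > 80000 nM in this assay, at which 2 of the 3 values shown sit.

On these data alone, whether 2-chloro-4-methylpyridin-3-yl in place of 5-methylpyridin-2-yl changes inhibition at all, and in which direction, stays open.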